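This account rests on a few compounds, and the source may have more. Where it says the series, first, only, none or still open, it means among the compounds named here.

In a functional assay on A549 cells (Homo sapiens) for inhibition (on this read-out higher numbers stand for weaker inhibition and lower numbers for stronger inhibition), compound 1 `COCCOc1cc(/C=C/c2ccc3ccccc3c2)ccc1OC` gives 2990 nM. Compound 2 `COCCOc1cc(/C=C\c2ccc3ccccc3c2)ccc1OC` gives 2990 nM, and compound 3 `Oc1ccc(/C=C/c2ccc3ccccc3c2)cc1` gives 4060 nM. These three numbers lie within the usual scatter of one another, so compound 1 stands level with the other two. Going by the values given here, the only measured step that changes a single place is no change at the digits printed from compound 1 to compound 2 (within the scatter), and it rests on (the fact that compounds 1 and 2 differ only in the configuration as drawn). Compound 4 `COc1ccc(/C=C/c2ccc3ccccc3c2)cc1N` keeps the shared core of compound 1 but swaps a substituent: amino in place of 2-methoxyethoxy on an aromatic carbon. The amino group takes the place of the 2-methoxyethoxy, ortho to a methoxy group. Among the compounds with values here, no measured step touches this substituent, so the configuration step offers only weak guidance. The numbers seen so far do sit close together, with compound 1 at 2990 nM and compound 3 at 4060 nM, so no shift beyond the scatter is expected in either direction. The expected step is a 1.5-fold lower number from compound 1 to compound 4 (0.17 log units; within the scatter). For compound 4 the estimated value is 2000 nM, with an expected range from 400 nM to 7000 nM.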

Compound 4, half-maximal inhibitory concentration: 1820 nM
Estimate against measurement, compound 4: 1.1-fold (0.04 log units) above; low and high end bracket the measured number.
By their numbers in this assay, from the lowest: compounds 4, 1, 2 and 3 (each within the scatter of the next, the first and the last beyond it).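

In this assay, going by these compounds alone, the earlier compounds showed only a change of configuration, whereas this pair changes the substituent itself on an aromatic carbon, ortho to a methoxy group. Replacing 2-methoxyethoxy, with 5 heavy atoms and 0 hydrogen-bond donors, by amino, with 1 heavy atom and 1 hydrogen-bond donor, gives a 1.6-fold lower number from compound 1 to compound 4 (0.22 log units; within the scatter) and so does not move the read-out beyond its usual scatter. At this place on the ring, then, a chain and a much smaller group read alike, at least for these two substituents.

On these data alone, whether a carboxylic acid or a longer ether chain at the same place would also read alike remains open. Nothing known here bears on why amino and 2-methoxyethoxy read alike.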